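A few compounds are considered here, and "the series" means these few. Any claim that something is new, unique, unknown or untested is made for them only; others in the source may bear on it.

Working notes on the series. Compound 1 `CN(C)c1ccc(C2SCC(=O)N2NC(=O)CN2C(=O)c3ccccc3C2=O)cc1` gives 2.84 in a physicochemical assay for lipophilicity, in phosphate buffer, measured as octanol-water partition, with a stated time of 24 h; a higher number here means a more lipophilic compound, a lower number a more polar compound. Compound 2 `COc1cc(C2SCC(=O)N2NC(=O)CN2C(=O)c3ccccc3C2=O)ccc1O` gives 1.31, and compound 3 `O=C(CN1C(=O)c2ccccc2C1=O)NN1C(=O)CSC1c1c[nH]c2ccccc12` gives 1.59. Compound 3 stands second highest of the three numbers; its nearest neighbour is compound 2, a gap within the scatter, while compound 1 lies far above it. The steps that touch the same saturated ring carbon are a number 1.53 log units lower from compound 1 to compound 2 (beyond the scatter), a number 1.25 log units lower from compound 1 to compound 3 (beyond the scatter) and a number 0.28 log units higher from compound 2 to compound 3 (within the scatter): swapping the group on that carbon has moved the number by more than a full unit in two cases and left it unchanged in the third.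

Compound 4 `O=C(CN1C(=O)c2ccccc2C1=O)NN1C(=O)CSC1c1ccco1` carries the change (furan-2-yl in place of 1H-indol-3-yl on a saturated ring carbon). Within the data shown here, no measured step involves furan-2-yl, so the expectation rests on the size of the replaced group alone. Since the large steps ran downward from compound 1, a downward step of moderate size is expected here, and the expected step is a number 0.69 log units lower from compound 3 to compound 4 (beyond the scatter). Compound 4 is therefore estimated at 0.9, within a range from 0.3 to 1.5.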

Compound 4, partition coefficient: 1.13
For compound 4 the middle estimate is 0.23 log units below the measured one; the range from low to high includes it.
By their numbers in this assay, from the lowest: compounds 4, 2 and 3 (each within the scatter of the next, the first and the last beyond it); then compound 1.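

In this assay the furan-2-yl group on this saturated ring carbon gives a modest step from the larger 1H-indol-3-yl group (a number 0.46 log units lower from compound 3 to compound 4 (beyond the scatter)). Against 4-hydroxy-3-methoxyphenyl no difference can be read (a number 0.18 log units lower from compound 2 to compound 4 (within the scatter)), whereas the step from 4-(dimethylamino)phenyl is the largest at this position so far (a number 1.71 log units lower from compound 1 to compound 4 (beyond the scatter)), which leaves compound 1 far from the other three. No measurement at hand offers a reason for any of these steps.

Every group shown at this carbon is an aromatic ring, so the effect of a piperidine, a carboxylic acid or a plain alkyl chain there remains open. Also open, going by these compounds, is whether these four groups keep their order when the shared core is changed elsewhere.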